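Swapping the Aryl Group on the Ring Nitrogen of Compound 3

The source may hold more compounds than are shown below. What is called first, only, known or untested is meant among the compounds shown, and "the series" means these compounds.

Compound 3 `COc1cc(F)ccc1N1C(=O)CSC1c1cccc(C(=O)NCCCCc2ccccc2)c1` carries a 4-fluoro-2-methoxyphenyl on an amide-type nitrogen in a ring. In a functional assay on MG-63 cells (Homo sapiens) for inhibition, read by CCK-8 assay, with a stated time of 72 h, tested at 1 uM (a higher number here means more inhibition at the concentration tested (going by the name of the read-out), a lower number less inhibition), compound 3 gives 92%. Compound 1 `COc1ccc(OC)c(N2C(=O)CSC2c2cccc(C(=O)NCCCCc3ccccc3)c2)c1` gives 92% in this assay, and the step of no change at the digits printed from compound 1 to compound 3 (within the scatter) places the two level at the digits shown, together the highest of the three numbers. Compound 2 `CCN1C(=O)CSC1c1cccc(C(=O)NCCCCc2ccccc2)c1`, which bears an ethyl on the same nitrogen, gives 0% in this assay; the step of a number 92 percentage points higher from compound 2 to compound 3 (beyond the scatter) is the largest in the set, and a number 92 percentage points lower from compound 1 to compound 2 (beyond the scatter) matches it in size.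

Compound 4 `O=C(NCCCCc1ccccc1)c1cccc(C2SCC(=O)N2c2cccc(F)c2)c1` has not yet been measured. Its change from compound 3 is 3-fluorophenyl in place of 4-fluoro-2-methoxyphenyl on an amide-type nitrogen in a ring. Within the data shown here, the steps that bear on it show that an aryl group at this position, against ethyl, made the whole difference in this assay, while exchanging 2,5-dimethoxyphenyl for 4-fluoro-2-methoxyphenyl changed nothing. Among the measured compounds shown here, compound 4 keeps an aryl group but gives up the methoxy, and no measured step tests that loss on its own, so the expectation leans toward a retained value with wide uncertainty. For compound 4 the estimated value in this assay is 75%, with a range from 30% to 95%. This estimate corresponds to an expected step of a number 17 percentage points lower from compound 3 to compound 4 (beyond the scatter).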

Compound 4, a percentage reported as inhibition, at one concentration (the size of the read-out at that concentration, not a potency): 92%
Beside the measured number, compound 4's estimate is 17 percentage points below it, within the range that was stated.
By their numbers in this assay, from the lowest: compound 2; then compounds 1, 3 and 4 (each within the scatter of the next).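

In this assay, the step of no change at the digits printed from compound 3 to compound 4 (within the scatter) shows that the aryl group on this amide-type nitrogen in a ring can lose its methoxy while the fluorine stands in a different place on the ring, with no visible cost; until now, every aryl group tested had carried at least one methoxy. The step of no change at the digits printed from compound 1 to compound 4 (within the scatter) points the same way for a phenyl with no methoxy at all, and the step of a number 92 percentage points higher from compound 2 to compound 4 (beyond the scatter) shows that 3-fluorophenyl alone is enough to separate this compound from the ethyl analogue of compound 2, so the requirement seen so far is met by a far simpler aryl group than the earlier ones. Nothing among the available data explains why these aryl groups behave alike or why ethyl differs from them.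

The compounds shown leave open whether a plain phenyl, a benzyl, a pyridyl ring, or an aryl group bearing an amine or a carboxylic acid would hold the same level at this nitrogen. With compounds 1, 3 and 4 level at a single tested concentration, they also leave open whether these three would separate at lower concentrations.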